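The source may report more compounds than this note shows. Statements on the series, on what has been measured and on what is new or still open speak of the compounds shown alone.

Working notes on the thiazole amide series in an ADME assay on P388D1 cells (Mus musculus) for cytotoxicity, read by fluorescence and resazurin assay, with a stated time of 72 h; a higher number here means a weaker inhibitor, a lower number a stronger inhibitor.

Four compounds are in view. Compound 1 `O=C(Nc1ncc(Cc2cccc3ccccc23)s1)C1CCCCC1` carries a naphthalene-bearing side chain; compound 3 `O=C(CCC1CCCCC1)Nc1ncc(Cc2cccc3ccoc23)s1` a benzofuran-bearing one on a longer acyl chain; compound 2 `CCc1cnc(NC(=O)C2CCCCC2)s1` a short ethyl group; compound 4 `O=C(Nc1ncc(Cc2ccccn2)s1)C1CCCCC1` a (pyridin-2-yl)methyl group in the same position.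

In this assay compound 1 returns only a limit, > 40000 nM, so no number is available for it; it sits at the limit of > 40000 nM in this assay, at which 1 of the 3 values shown sits. In this assay compound 3 gives 17800 nM. For compound 2 this assay reports "not determined" (no result reported), so compound 2 stands without a value among the numbers shown.

The change from compound 2 to compound 4 is pyridin-2-yl in place of methyl on a saturated chain carbon bound to an aromatic carbon. Going by the values given here, no measured step matches it, so the size of the expected effect rests on the two neighbours only: compound 1 at its limit and compound 3 at a weak but measurable value. A modest shift towards a weak result, if any, is expected in this assay, likely not beyond the scatter of the assay itself. Compound 4 is estimated at 30000 nM, within 8000 nM to 100000 nM, with a fair chance that only a limit is reported.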

Compound 4, half-maximal inhibitory concentration: > 40000 nM
Compound 4 was reported as a limit (the forecaster's own chance of this, stated with the estimate: 40%); middle value at least 1.3-fold (0.12 log units) from the limit.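

No step can be read between compound 2 and compound 4 in this assay: compound 2 stands without a value, and compound 4 gives only a limit. Compound 4 returns a limit of the assay, not a number: the limit of > 40000 nM in this assay, at which 2 of the 4 values shown sit.

The compounds shown leave open how the (pyridin-2-yl)methyl group of compound 4 compares with the ethyl group of compound 2 in this read-out.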